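Furan-2-yl in place of 2,6-dimethylphenyl: working notes

A few compounds are considered here, and "the series" means these few. Any claim that something is new, unique, unknown or untested is made for them only; others in the source may bear on it.

In a functional assay on KB cells (Homo sapiens) for cytotoxicity (a higher number here means that more compound is needed for the effect, a lower number that less compound is needed), compound 1 `COC1=C(C)C(=O)/C(=C(O)/C=C/c2ccc(F)cc2)C(=O)C1(C)C` gives 2.7 ug/mL and compound 2 `COC1=C(C)C(=O)/C(=C(O)/C=C/c2c(C)cccc2C)C(=O)C1(C)C` gives 2.1 ug/mL. Within the data shown here, these two values lie within the scatter of each other, so compound 2 does not stand apart from compound 1 on the numbers so far.

The next structure, compound 3 `COC1=C(C)C(=O)/C(=C(O)/C=C/c2ccco2)C(=O)C1(C)C`, has furan-2-yl in place of 2,6-dimethylphenyl on a double-bonded chain carbon bound to a double-bonded chain carbon.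

Among the measured compounds shown here, one measured step bears on this change, at the same place on the chain: a 1.3-fold lower number from compound 1 to compound 2 (0.11 log units; within the scatter). It swaps one six-membered aromatic ring of carbon only for another, and it stays within the scatter. For the measured compounds named here, no measured compound carries a five-membered aromatic ring with a hetero atom, so this evidence is indirect and the range has to stay wide. No step beyond the scatter is expected in this assay, and no direction is favoured with any confidence. The expected step is a 1.2-fold higher number from compound 2 to compound 3 (0.08 log units; within the scatter). For compound 3 the estimated value is 2.5 ug/mL, with an expected range from 1 ug/mL to 6 ug/mL.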

Compound 3, concentration for half-maximal effect: 8.8 ug/mL
Estimate against measurement, compound 3: 3.5-fold (0.55 log units) below; the whole stated range lies below it.
By their numbers in this assay, from the lowest: compounds 2 and 1 (each within the scatter of the next); then compound 3.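

At this place on the chain, the aromatic ring is not interchangeable in this assay, although the two six-membered aromatic rings of carbon only had not been told apart. Furan-2-yl gives a step beyond the scatter against either of them (a 4.2-fold higher number from compound 2 to compound 3 (0.62 log units; beyond the scatter); a 3.3-fold higher number from compound 1 to compound 3 (0.51 log units; beyond the scatter)), so the shift does not depend on which of the two serves as the reference, and both steps run the same way. Nothing available on these compounds explains the step.

Furan-2-yl differs from the groups it is compared with in several ways at once: the ring is five-membered, it holds an oxygen and a hydrogen-bond acceptor, and it has fewer heavy atoms than 2,6-dimethylphenyl, so the compounds shown cannot say which of these differences goes with the higher number. Thiophen-2-yl or unsubstituted phenyl at the same place would help to separate these differences, while a ring carrying an amine or a carboxylic acid would show whether any group here gives a number clearly lower than those of the two six-membered rings.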